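Ester to Primary Amide on a Shared Thiazole Core

The source may report more compounds than this note shows. Statements on the series, on what has been measured and on what is new or still open speak of the compounds shown alone.

Measured so far in a functional assay on Raji cells (Homo sapiens) for antiproliferative activity, read by CCK-8 assay, with a stated time of 72 h, tested at 40 uM; on this read-out lower numbers stand for less inhibition and higher numbers for more inhibition at the one concentration tested (going by the name of the read-out):
compound 1 `CCOC(=O)c1sc(-c2cccc(NC(=O)c3ccccc3)c2)nc1Nc1ccc(N2CCN(C)CC2)cc1` gives 42%;
compound 2 `CCOC(=O)c1sc(-c2cccc(NC(=O)c3ccccc3F)c2)nc1Nc1ccc(N2CCN(C)CC2)cc1` gives 89.8%;
compound 3 `CCOC(=O)c1sc(-c2cccc(NC(=O)c3ccco3)c2)nc1Nc1ccc(N2CCN(C)CC2)cc1` gives 87.6%.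

On these numbers compound 3 stands second highest of the three. Its value lies within the usual scatter of compound 2, so no order between those two can be claimed, while it sits well above compound 1. Compound 4 `CN1CCN(c2ccc(Nc3nc(-c4cccc(NC(=O)c5ccco5)c4)sc3C(N)=O)cc2)CC1` differs from compound 3 in one place: amino in place of ethoxy on a carbonyl carbon.

For the measured compounds named here, none of the measured steps touches this part of the molecule. The two large steps, a number 47.8 percentage points higher from compound 1 to compound 2 (beyond the scatter) and a number 45.6 percentage points higher from compound 1 to compound 3 (beyond the scatter), and the small step of a number 2.2 percentage points lower from compound 2 to compound 3 (within the scatter) all change the group named in them, not the ethoxy group. They give no direct guide to the size or direction of the ethoxycarbonyl to carbamoyl change in this assay, so the expectation rests on compound 3 alone, with a wide range around it. Compound 4 is expected near 75%, between 45% and 95%. The expected step is a number 12.6 percentage points lower from compound 3 to compound 4 (beyond the scatter), a change not expected to exceed the scatter.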

Compound 4, a percentage reported as inhibition, at one concentration (the size of the read-out at that concentration, not a potency): 84.3%
Compound 4: middle estimate off by 9.3 percentage points, on the low side; low and high end bracket the measured number.
By their numbers in this assay, from the lowest: compound 1; then compounds 4, 3 and 2 (each within the scatter of the next).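

In this assay, the change from ethoxycarbonyl to carbamoyl gives a number 3.3 percentage points lower from compound 3 to compound 4 (within the scatter). With the furan-2-yl amide in place, the ester and the primary amide therefore cannot be told apart at this position, even though the amino group is smaller than ethoxy and brings a hydrogen-bond donor where ethoxy has none. Nothing available here explains why the two read alike.

This single pair does not show whether the same change would read alike with the benzamide of compound 1, which gives 42%, or with the 2-fluorophenyl amide of compound 2. It also leaves open what a carboxylic acid, a methyl amide or a longer ester chain would do on this carbonyl carbon, and, with only one concentration tested, whether potency shifts.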